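Solubility notes on a benzylamine-linked aminoquinoline series

This account rests on a few compounds, and the source may have more. Where it says the series, first, only, none or still open, it means among the compounds named here.

Compound 1 `COc1cccc(CNCCCNc2ccnc3cc(Cc4cc(C)cc(C)c4)ccc23)c1O`, compound 2 `COc1cccc(CNCCCNc2ccnc3cc(Cc4ccc(F)cc4)ccc23)c1O` and compound 3 `COc1cccc(CNCCCNc2ccnc3cc(Cc4cccc(C(F)(F)F)c4)ccc23)c1O` share one core and differ only in the aryl group carried on a saturated chain carbon bound to an aromatic carbon. In a physicochemical assay for solubility, with a stated time of 18 h, at pH 7.4 (on this read-out higher numbers stand for higher solubility and lower numbers for lower solubility), compound 1 gives 4200 nM, compound 2 gives 4200 nM and compound 3 gives 4200 nM. The three steps among them, no change at the digits printed from compound 1 to compound 2 (within the scatter), no change at the digits printed from compound 1 to compound 3 (within the scatter) and no change at the digits printed from compound 2 to compound 3 (within the scatter), are all flat: exchanging 3,5-dimethylphenyl, 4-fluorophenyl and 3-(trifluoromethyl)phenyl on that chain carbon moves nothing. Going by the values given here, compound 3 therefore stands level with compound 1 and compound 2 in this assay, with no member set apart.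

Compound 4 `COc1cccc(CNCCCNc2ccnc3cc(-c4ccccc4)ccc23)c1O` is not yet measured. Its difference from compound 3 is phenyl in place of 3-(trifluoromethyl)benzyl on an aromatic carbon, a change that removes the saturated chain carbon together with the trifluoromethyl group rather than swapping one aryl substituent for another. Among the compounds with values here, no measured step covers the loss of that chain carbon; the measured steps bear on it only insofar as they show this assay insensitive to the aryl portion in the three compounds seen. On that basis the expected step from compound 3 to compound 4 is no change at the digits printed from compound 3 to compound 4 (within the scatter), none beyond the scatter. Within the data shown here, compound 4 is expected to give 4200 nM in this assay, within a range from 1500 nM to 12000 nM that is set wider than the scatter alone because no measured step addresses this kind of change.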

Compound 4, solubility: 32000 nM
For compound 4 the middle estimate is 7.6-fold (0.88 log units) below the measured one; the measured number lies above the stated range.
By their numbers in this assay, from the lowest: compounds 1, 2 and 3 (each within the scatter of the next); then compound 4.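

Exchanging the aryl group on the retained chain carbon left this assay flat, but this aromatic carbon of the shared core is not insensitive to every change: phenyl in place of 3-(trifluoromethyl)benzyl gives a 7.6-fold higher number from compound 3 to compound 4 (0.88 log units; beyond the scatter) and phenyl in place of 4-fluorobenzyl gives a 7.6-fold higher number from compound 2 to compound 4 (0.88 log units; beyond the scatter) while phenyl in place of 3,5-dimethylbenzyl gives a 7.6-fold higher number from compound 1 to compound 4 (0.88 log units; beyond the scatter) in the same comparison. Going by these compounds alone, the flat steps among compounds 1, 2 and 3 therefore describe only exchanges that keep the saturated chain carbon, and the one change that removes that carbon is also the one step set that lies beyond the scatter, with compound 4 standing apart from all three. Nothing measured here bears on the reason for this rise.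

An unsubstituted benzyl group on this aromatic carbon would separate loss of the chain carbon from loss of the trifluoromethyl, fluoro or methyl substituents, which all three steps to compound 4 remove together. Also open, from the compounds shown here alone, is how a longer chain carrying the phenyl ring, or a phenyl ring bearing trifluoromethyl, an amine or a carboxylic acid, would read on this scale.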